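Methyl to Nitrile on the Benzylic Ring of a Hydroxamic Acid

The compounds below may be only part of what the source reports. "The series", "measured", "known", "first", "only" and "open" are said of these compounds alone.

Compound 1 `Cc1cccc(CN2CC=C(CCC(=O)NO)C2=O)c1` and compound 2 `O=C(CCC1=CCN(Cc2ccc(Br)cc2F)C1=O)NO` share a core that carries a hydroxamic acid on a short chain and a substituted benzyl group on the ring nitrogen. In a functional assay on NUGC-3 cells (Homo sapiens) for inhibition, read by sulforhodamine B assay (on this read-out lower numbers stand for stronger inhibition of growth and higher numbers for weaker inhibition of growth), compound 1 gives 4280 nM, and in this assay compound 2 gives 4280 nM. The two values agree at the digits shown, so compound 1 stands level with compound 2, and nothing separates them beyond the usual scatter of this kind of measurement.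

Compound 3 `N#Cc1cccc(CN2CC=C(CCC(=O)NO)C2=O)c1` has not yet been measured. It differs from compound 1 in one place: cyano in place of methyl on an aromatic carbon. The ring, the chain and the hydroxamic acid are otherwise unchanged.

Within the data shown here, no measured pair here shows what such an exchange does, and the one comparison available, between compound 1 and compound 2, shows that a different pattern of substituents on this ring left the read-out unchanged. On that basis the step of a 1.1-fold lower number from compound 1 to compound 3 (0.03 log units; within the scatter) is expected to stay within the scatter, with no clear direction. Compound 3 is therefore estimated at 4000 nM in this assay, with a likely range from 1500 nM to 11000 nM.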

Compound 3, concentration for 50% growth inhibition: 4120 nM
Compound 3: middle estimate off by 1.0-fold (0.01 log units), on the low side; the measured number falls inside the stated range.
By their numbers in this assay, from the lowest: compounds 3, 1 and 2 (each within the scatter of the next).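

In this assay, putting cyano in place of methyl on this aromatic carbon, meta to a large group, gives a 1.0-fold lower number from compound 1 to compound 3 (0.02 log units; within the scatter), so the read-out does not separate the two groups at this position. Among these compounds, this is the first direct look at a single exchange on the benzyl ring, since compound 1 and compound 2 differ in more than one place and could not isolate the effect of any one group. Here, a cyano group, with one more heavy atom than methyl and a hydrogen-bond acceptor that methyl lacks, leaves growth inhibition level with that of compound 1, although nothing measured here offers an explanation for this result.

Going by these compounds, what remains open is whether this position tolerates groups of other kinds, such as an amine or a carboxylic acid, or whether the level result holds only for the small pair compared here. It is also unknown whether the same exchange would give a level result on another carbon of the ring, or whether a longer chain in place of methyl would shift the number beyond the scatter.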